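Swapping a methoxy for a vinyl on the chain of compound 1

The compounds below may be only part of what the source reports. "The series", "measured", "known", "first", "only" and "open" are said of these compounds alone.

Measured compounds:
compound 1, `COCc1cc(C(C)=O)c(O)cc1OCCCCCCC#N`, 47%
compound 2, `CC(=O)c1cc(CC(C)O)c(OCCCCC#N)cc1O`, 10%

Of the compounds shown here, two have been measured in an assay on isolated protein for inhibition of leukotriene B4 receptor 1 (Homo sapiens), tested at 10 uM; on this read-out lower numbers stand for less inhibition and higher numbers for more inhibition at the one concentration tested (going by the name of the read-out). Compound 1 stands highest of the two numbers; its nearest neighbour, compound 2, gives 10%, a value lower by a margin beyond the usual scatter. The two differ in more than one place, so their values alone show the gap without telling which change carries it.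

Compound 3, `C=CCc1cc(C(C)=O)c(O)cc1OCCCCCCC#N`, has not yet been measured in this assay. Its difference from compound 1 is counted as vinyl in place of methoxy on a saturated chain carbon bound to an aromatic carbon. Within the data shown here, no single-change step among the measured compounds informs this swap, so the step of a number 2 percentage points lower from compound 1 to compound 3 (within the scatter) is expected to be small, none beyond the scatter, in either direction. Compound 3 is therefore estimated at about 45%, with a range from 20% to 70%.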

Compound 3, a percentage reported as inhibition, at one concentration (the size of the read-out at that concentration, not a potency): 97%
Beside the measured number, compound 3's estimate is 52 percentage points below it, and the stated range ends below it.
By their numbers in this assay, from the lowest: compound 2; then compound 1; then compound 3.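

In this assay, among these compounds, the single change of methoxy to vinyl on a saturated chain carbon bound to an aromatic carbon gives a number 50 percentage points higher from compound 1 to compound 3 (beyond the scatter) and is the first step in this set that can be read in one place. It shows that this position is not indifferent to what it carries, even when the heavy-atom count of the group stays the same and the change consists of an oxygen with its hydrogen-bond acceptor leaving and a double bond entering. Nothing measured here explains the size of this step.

The compounds shown leave open whether the double bond or the loss of the oxygen carries the step. They also leave open how an amine, a carboxylic acid or a longer chain would read at this same place.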